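Aryl swaps on the shared core: from compound 3 to compound 4

The source may hold more compounds than are shown below. What is called first, only, known or untested is meant among the compounds shown, and "the series" means these compounds.

Measured in a functional assay on HCC827 cells (Homo sapiens) for inhibition, read by fluorescence, with a stated time of 72 h; a higher number here means a weaker inhibitor of growth, a lower number a stronger inhibitor of growth:
compound 1 `COc1ccc(Nc2nc(N[C@H]3CC[C@H](N)CC3)nc3c2ncn3CCC(C)C)c(OC)c1`: 32900 nM
compound 2 `CC(C)CCn1cnc2c(Nc3ccc(Cl)cc3)nc(N[C@H]3CC[C@H](N)CC3)nc21`: 10200 nM
compound 3 `COc1cc(Nc2nc(N[C@H]3CC[C@H](N)CC3)nc3c2ncn3CCC(C)C)cc(OC)c1`: 11200 nM

Compound 3 stands with compound 2 in the lower pair of numbers, while compound 1 sits apart from both. The next change leads to compound 4 `CC(C)CCn1cnc2c(Nc3ccccc3)nc(N[C@H]3CC[C@H](N)CC3)nc21`: phenyl in place of 3,5-dimethoxyphenyl on a nitrogen on an aromatic ring. In words, this is phenyl in place of 3,5-dimethoxyphenyl on a nitrogen on an aromatic ring.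

For the measured compounds named here, no measured step makes this exact change, so the evidence is indirect. The nearest is the swap of 4-chlorophenyl for 3,5-dimethoxyphenyl, a 1.1-fold higher number from compound 2 to compound 3 (0.04 log units; within the scatter). The two larger steps, a 3.2-fold lower number from compound 1 to compound 2 (0.51 log units; beyond the scatter) and a 2.9-fold lower number from compound 1 to compound 3 (0.47 log units; beyond the scatter), both start from 2,4-dimethoxyphenyl, a group not involved in this change. With only these three compounds, the basis is thin, but no step beyond the scatter is expected in this assay.

The expected step is a 1.1-fold higher number from compound 3 to compound 4 (0.03 log units; within the scatter).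

Compound 4 is estimated at 12000 nM, with an expected range of 5000 nM to 28000 nM.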

Compound 4, concentration for 50% growth inhibition: 21700 nM
Estimate against measurement, compound 4: 1.8-fold (0.26 log units) below, and the stated range covers the measured number.
By their numbers in this assay, from the lowest: compounds 2, 3, 4 and 1 (each within the scatter of the next, the first and the last beyond it).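

In this assay, for the compounds shown here, phenyl gives the series its unsubstituted aryl reference, and removing the chloro group is the only one of these changes that reads beyond the scatter (a 2.1-fold higher number from compound 2 to compound 4 (0.33 log units; beyond the scatter)). Phenyl does not separate from either dimethoxyphenyl group (a 1.9-fold higher number from compound 3 to compound 4 (0.29 log units; within the scatter); a 1.5-fold lower number from compound 1 to compound 4 (0.18 log units; within the scatter)), so neither pair of methoxy groups shows a readable effect against the unsubstituted ring. No measured evidence accounts for these results.

Still open, on these data alone, is whether an amine or a carboxylic acid on the phenyl ring would move the number beyond the scatter in either direction. As far as these compounds go, it is also open whether bromo or fluoro in place of chloro would give a step like the one seen for chloro, and whether a benzyl or cyclohexyl group on this nitrogen would behave like the aryl groups.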